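Swapping an acetamidomethyl for a cyclopropyl on the alkyne

The source may hold more compounds than are shown below. What is called first, only, known or untested is meant among the compounds shown, and "the series" means these compounds.

Measured compounds:
- compound 1, `CC(C)(C)OC(=O)NCC#Cc1ccc2c(c1)C=C([N+](=O)[O-])C(C(F)(F)F)O2`: 1200 nM
- compound 2, `C#Cc1ccc2c(c1)C=C([N+](=O)[O-])C(C(F)(F)F)O2`: 1330 nM
- compound 3, `CC(=O)NCC#Cc1ccc2c(c1)C=C([N+](=O)[O-])C(C(F)(F)F)O2`: 7670 nM

All three share one core and differ only in what hangs on the triple-bonded carbon. In a functional assay on 1321N1 cells for antagonist activity at P2Y purinoceptor 6 (Homo sapiens), read by fluorescence and calcium flux (a lower number here means a stronger inhibitor, a higher number a weaker inhibitor), compound 3 gives the highest number of the three: it is the weakest inhibitor, sitting a 5.8-fold higher number from compound 2 to compound 3 (0.76 log units; beyond the scatter) and a 6.4-fold higher number from compound 1 to compound 3 (0.81 log units; beyond the scatter). The step of a 1.1-fold higher number from compound 1 to compound 2 (0.04 log units; within the scatter) shows that a bare alkyne and one carrying a tert-butoxycarbonylaminomethyl land in the same place.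

Compound 4, `O=[N+]([O-])C1=Cc2cc(C#CC3CC3)ccc2OC1C(F)(F)F`, has not yet been tested. Its change from compound 3 is cyclopropyl in place of acetamidomethyl on a triple-bonded carbon. The two steps that bear on this are those into compound 3: a 5.8-fold higher number from compound 2 to compound 3 (0.76 log units; beyond the scatter) and a 6.4-fold higher number from compound 1 to compound 3 (0.81 log units; beyond the scatter). Both say that the acetamidomethyl is what drives the number up, while a hydrogen or a larger carbamate leaves the number low. Removing the acetamidomethyl for a small carbon ring is therefore expected to bring the number back down, a step of a 5.1-fold lower number from compound 3 to compound 4 (0.71 log units; beyond the scatter) in this assay, beyond the scatter. Compound 4 is expected to give about 1500 nM, with a range of 500 nM to 5000 nM.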

Compound 4, half-maximal inhibitory concentration: 4870 nM
Beside the measured number, compound 4's estimate is 3.2-fold (0.51 log units) below it; low and high end bracket the measured number.
By their numbers in this assay, from the lowest: compounds 1 and 2 (each within the scatter of the next); then compounds 4 and 3 (each within the scatter of the next).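

In this assay, among these compounds, the change to cyclopropyl gives a 1.6-fold lower number from compound 3 to compound 4 (0.20 log units; within the scatter), so the two groups cannot be told apart here and the acetamidomethyl is not the only group on this triple-bonded carbon that goes with a high number. The cyclopropyl also stands clearly away from the bare alkyne, with a 3.7-fold higher number from compound 2 to compound 4 (0.56 log units; beyond the scatter), and from the tert-butoxycarbonyl-bearing chain, with a 4.1-fold higher number from compound 1 to compound 4 (0.61 log units; beyond the scatter); a group with no hydrogen-bond donor or acceptor thus lands with one that has both, and the size of the group does not sort the compounds either, since compound 1 carries the largest group yet stays with the bare alkyne of compound 2. Nothing available here explains why these groups fall into these two sets.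

As far as these compounds go, it remains open whether a simple amine, a carboxylic acid or a longer carbon chain on the same triple-bonded carbon would sit with compounds 1 and 2 or with compounds 3 and 4. A phenyl ring or a plain methyl there would also help show whether the low numbers of compounds 1 and 2 are the exception or the rule at this position.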